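Fluoromethyl replaces tert-butyl in a diaryl urea series

The source may hold more compounds than are shown below. What is called first, only, known or untested is meant among the compounds shown, and "the series" means these compounds.

Measured compounds:
Compound 1 `CNc1cc(Oc2ccc(NC(=O)Nc3cccc(C(C)(F)F)c3)cc2)ncn1`: 40 nM
Compound 2 `CNc1cc(Oc2ccc(NC(=O)Nc3cccc(C(C)(C)C)c3)cc2)ncn1`: 40 nM

In an assay on isolated protein for inhibition of serine/threonine-protein kinase TNNI3K (Homo sapiens) (on this read-out lower numbers stand for stronger inhibition and higher numbers for weaker inhibition), compound 1 gives 40 nM and compound 2 gives 40 nM. The step from the first to the second, no change at the digits printed from compound 1 to compound 2 (within the scatter), stayed within the scatter, so compound 2 stands level with compound 1 on these numbers; nothing separates them.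

Compound 3 `CNc1cc(Oc2ccc(NC(=O)Nc3cccc(CF)c3)cc2)ncn1` differs from compound 2 by fluoromethyl in place of tert-butyl on an aromatic carbon. Among the compounds with values here, only the step from compound 1 to compound 2 bears on it, and that step showed no change beyond the scatter when one group at this position was exchanged for another. The present exchange removes more of the group than that step did, so a small step toward weaker inhibition in this assay is expected, though it may not exceed the scatter. For compound 3 the estimate is 80 nM, with a range from 30 nM to 250 nM, corresponding to an expected step of a 2.0-fold higher number from compound 2 to compound 3 (0.30 log units; within the scatter).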

Compound 3, half-maximal inhibitory concentration: 400 nM
For compound 3 the middle estimate is 5.0-fold (0.70 log units) below the measured one; the whole stated range lies below it.
By their numbers in this assay, from the lowest: compounds 1 and 2 (each within the scatter of the next); then compound 3.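

In this assay this position proves sensitive to the group it carries: fluoromethyl in place of tert-butyl gives a 10-fold higher number from compound 2 to compound 3 (1.00 log units; beyond the scatter) and fluoromethyl in place of 1,1-difluoroethyl gives a 10-fold higher number from compound 1 to compound 3 (1.00 log units; beyond the scatter). The level values of compound 1 and compound 2 had therefore not shown that any group is accepted here, since fluoromethyl, with 2 heavy atoms against 4 for tert-butyl, stands apart from both. Nothing at hand accounts for this loss.

The compounds shown leave open whether the loss follows the size of the group or the fluorine it carries, a question that methyl, ethyl or trifluoromethyl at this position would help to separate. Also open, on these data alone, is how an amine or a longer chain would fare here.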